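Extending the Methoxy Arm: Expected Tolerance of Compound 4

This account rests on a few compounds, and the source may have more. Where it says the series, first, only, none or still open, it means among the compounds named here.

Compound 1, `O=C(Nc1ccc(Cl)cc1)c1ccc([N+](=O)[O-])o1`, gives 1500 nM in an ADME assay on Vero cells (Chlorocebus sabaeus) for cytotoxicity, read by MTT assay, with a stated time of 48 h; a higher number here means that more compound is tolerated, a lower number that less compound is tolerated.
Compound 2, `O=C(Nc1cc2ccccc2o1)c1ccc([N+](=O)[O-])o1`, gives 40000 nM in this assay.
Compound 3, `COc1ccc(C(C)(C)NC(=O)c2ccc([N+](=O)[O-])o2)cc1`, gives 82000 nM in this assay.

Compound 3 has the highest number of the three in this assay. Compound 2 stands nearest, with a lower number, and that gap lies beyond the usual scatter; compound 1 stands furthest below. Compound 4, `COc1ccc(OCc2ccc(C(C)(C)NC(=O)c3ccc([N+](=O)[O-])o3)cc2)cc1`, has not yet been measured. It differs from compound 3 in one place: (4-methoxyphenoxy)methyl in place of methoxy on an aromatic carbon. Going by the values given here, no step between two measured compounds shows what such a change does here, so any expectation rests on the three numbers alone. In this assay a downward step of moderate size, somewhat beyond the scatter, is expected, estimated as a 2.3-fold lower number from compound 3 to compound 4 (0.37 log units; beyond the scatter). Compound 4 is thus expected to give about 35000 nM, within a range from 8000 nM to 110000 nM.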

Compound 4, half-maximal cytotoxic concentration: > 120000 nM
Compound 4: a limit, no number; the forecaster's own chance of this, stated with the estimate: 20%; middle value at least 3.4-fold (0.53 log units) from the limit.
By their numbers in this assay, from the lowest: compound 1; then compound 2; then compound 3. At a limit, above all of these: compound 4.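

Going by these compounds alone, on an aromatic carbon para to a large group, the far bulkier (4-methoxyphenoxy)methyl can replace methoxy with no loss of tolerance in this assay, the first direct look at a change at this position: the step is an at least 1.4-fold higher number from compound 3 to compound 4 (0.16 log units; that floor lies within the scatter). For compound 4, > 120000 nM is a limit and not a number: the limit of > 120000 nM in this assay, at which 1 of the 4 values shown sits.

As far as these compounds go, how far compound 4 really lies beyond that limit stays open. So does whether an amine or a carboxylic acid at the end of the same arm would be tolerated equally well.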